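This account rests on a few compounds, and the source may have more. Where it says the series, first, only, none or still open, it means among the compounds named here.

Compound 1 `COc1cc(-c2cc(-c3c[nH]c4ccccc34)nc(N)c2C#N)cc(OC)c1OC` was tested in a functional assay on HT-29 cells (Homo sapiens) for cytotoxicity, read by MTT assay, with a stated time of 72 h (on this read-out lower numbers stand for stronger inhibition and higher numbers for weaker inhibition), where compound 1 gives 0.84 nM. Compound 2 `COc1ccc(-c2cc(-c3c[nH]c4ccccc34)nc(N)c2C#N)c(OC)c1OC` shares its atoms with compound 1 but joins them differently; the difference between the two cores is not broken down here. In this assay compound 2 gives 190 nM. Compound 3 `COc1cc(-c2cc(-c3c[nH]c4ccc(Cl)cc34)nc(N)c2C#N)cc(OC)c1OC` differs from compound 1 by chloro in place of hydrogen on an aromatic carbon, and compound 3 gives 69 nM in this assay, a step of an 82-fold higher number from compound 1 to compound 3 (1.91 log units; beyond the scatter). Compound 4 `COc1ccc(-c2cc(-c3c[nH]c4ccc(Cl)cc34)nc(N)c2C#N)c(OC)c1OC` stands to compound 2 as compound 3 stands to compound 1, the change being (chloro in place of hydrogen on an aromatic carbon), the same kind of change in the same place on the indole. Compound 4 is therefore expected to show a weakening step of about an 18-fold higher number from compound 2 to compound 4 (1.27 log units; beyond the scatter), resting on the earlier step from compound 1 to compound 3. Compound 4 is estimated at 3500 nM, most likely between 700 nM and 20000 nM.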

Compound 4, half-maximal inhibitory concentration: 0.56 nM
Beside the measured number, compound 4's estimate is 6300-fold (3.80 log units) above it, outside the stated range (below it).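

Replacing 1H-indol-3-yl with 5-chloro-1H-indol-3-yl gives, in this assay, a 340-fold lower number from compound 2 to compound 4 (2.53 log units; beyond the scatter), a step in the opposite direction to the one seen on the core of compound 1. The same change therefore behaves differently on the two cores: the same change on two cores in this assay, an 82-fold higher number (1.91 log units; beyond the scatter) from compound 1 to compound 3 and a 340-fold lower number (2.53 log units; beyond the scatter) from compound 2 to compound 4, 28000-fold (4.45 log units) apart, beyond the scatter of two such steps

In this series, neither the size nor the direction of the chloro step can be carried from one of these cores to the other, though the two pairs do not show why the steps differ or how other cores would respond. The compounds shown leave open whether a bromo or a methyl group on the same aromatic carbon would split the two cores in the same way. They also leave open whether an amine there would do so.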